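Ethoxy in place of fluoro: expected cytotoxicity

The source may hold more compounds than are shown below. What is called first, only, known or untested is meant among the compounds shown, and "the series" means these compounds.

Measured so far:
- compound 1, `COc1ccc2c(=O)c(/C=C/C(=O)NCc3ccccc3)coc2c1`: 376000 nM
- compound 2, `COc1ccc2c(=O)c(/C=C/C(=O)Nc3ccc(F)cc3)coc2c1`: 743000 nM

Going by the values given here, in an ADME assay on HepG2 2.2.15 cells (Homo sapiens) for cytotoxicity, read by MTT assay, with stated times of 48 h and 9 days (on this read-out lower numbers stand for higher toxicity in this test and higher numbers for lower toxicity in this test), compound 2 gives 743000 nM, and its only neighbour, compound 1, lies within the scatter of it: the step of a 2.0-fold higher number from compound 1 to compound 2 (0.30 log units; within the scatter) is too small to tell the two apart, so compound 2 is simply one of two similar numbers.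

Compound 3 `CCOc1ccc(NC(=O)/C=C/c2coc3cc(OC)ccc3c2=O)cc1` differs from compound 2 by ethoxy in place of fluoro on an aromatic carbon. Among the compounds with values here, the single measured step exchanged the whole group on the amide-type nitrogen and stayed within the scatter; no measured step changes a group on that aromatic ring, so nothing measured speaks for a move in either direction. The expectation is therefore no step beyond the scatter, a 1.1-fold lower number from compound 2 to compound 3 (0.06 log units; within the scatter). Compound 3 is expected to give about 650000 nM in this assay, with a likely range from 280000 nM to 1500000 nM.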

Compound 3, half-maximal cytotoxic concentration: 460000 nM
Estimate against measurement, compound 3: 1.4-fold (0.15 log units) above, within the range that was stated.
By their numbers in this assay, from the lowest: compounds 1, 3 and 2 (each within the scatter of the next).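

In this assay, going by these compounds alone, this is the first view of a change on the aromatic ring itself: ethoxy in place of fluoro, para to a large group, gives a 1.6-fold lower number from compound 2 to compound 3 (0.21 log units; within the scatter). A group with more heavy atoms and a hydrogen-bond acceptor can therefore stand at this position without a difference that can be told from the scatter, and exchanging the whole group on the amide-type nitrogen, with 4-ethoxyphenyl in place of benzyl, gives a 1.2-fold higher number from compound 1 to compound 3 (0.09 log units; within the scatter), so no two of the three compounds are yet separated by this test. Nothing available gives a reason for this lack of separation.

On these data alone, whether an amine or a carboxylic acid at this place on the ring would shift the number beyond the scatter stays open. So does the effect of a chain longer than ethoxy.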